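Working notes: changing the ring on the carbonyl carbon

The source may report more compounds than this note shows. Statements on the series, on what has been measured and on what is new or still open speak of the compounds shown alone.

Measured in a functional assay on DU-145 cells (Homo sapiens) for antiproliferative activity, read by MTT assay, with a stated time of 3 days; a lower number here means a stronger inhibitor, a higher number a weaker inhibitor:
- compound 1 `COc1cc(O)c2c(=O)cc(-c3ccc(NS(C)(=O)=O)cc3)oc2c1OC(C)C`: 19100 nM
- compound 2 `COc1cc(O)c2c(=O)cc(-c3ccc(NS(=O)(=O)C4CC4)cc3)oc2c1OC(C)C`: 48700 nM
- compound 3 `COc1cc(O)c2c(=O)cc(-c3ccc(NC(=O)N4CCCNCC4)cc3)oc2c1OC(C)C`: 36000 nM

Compound 3 stands within the scatter of both other measured compounds: a 1.9-fold higher number from compound 1 to compound 3 (0.28 log units; within the scatter), and a 1.4-fold lower number from compound 2 to compound 3 (0.13 log units; within the scatter). The next compound is compound 4 `COc1cc(O)c2c(=O)cc(-c3ccc(NC(=O)N4CC(C)NC(C)C4)cc3)oc2c1OC(C)C`, with the change 3,5-dimethylpiperazin-1-yl in place of 1,4-diazepan-1-yl on a carbonyl carbon. Within the data shown here, no measured step tests this exchange directly. The two steps that replace the whole group on the nitrogen, shown above, stayed within the scatter, and a 2.5-fold higher number from compound 1 to compound 2 (0.41 log units; beyond the scatter) is only modest. No step beyond the scatter is therefore expected in this assay, and no direction is favoured. The estimated step is a 1.0-fold lower number from compound 3 to compound 4 (0.01 log units; within the scatter). Compound 4 is expected at 35000 nM, with an estimated range of 15000 nM to 80000 nM.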

Compound 4, half-maximal inhibitory concentration: 41900 nM
For compound 4 the middle estimate is 1.2-fold (0.08 log units) below the measured one; the measured number falls inside the stated range.
By their numbers in this assay, from the lowest: compounds 1, 3, 4 and 2 (each within the scatter of the next, the first and the last beyond it).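

In this assay, among these compounds, the first direct exchange on this carbonyl carbon, from the seven-membered 1,4-diazepan-1-yl to the six-membered 3,5-dimethylpiperazin-1-yl, stays within the scatter (a 1.2-fold higher number from compound 3 to compound 4 (0.07 log units; within the scatter)), so this pair does not separate the two rings. Against the sulfonamides, the new urea-type compound is also within the scatter of the cyclopropylsulfonyl compound (a 1.2-fold lower number from compound 2 to compound 4 (0.07 log units; within the scatter)), while the step from the methylsulfonyl compound is modest but beyond it (a 2.2-fold higher number from compound 1 to compound 4 (0.34 log units; beyond the scatter)). No evidence on the cause of these steps is available.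

Ring size and the two methyl groups change together here, so their separate contributions remain open. Piperazin-1-yl without methyl groups on the same carbonyl carbon would separate them.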